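The compounds below may be only part of what the source reports. "The series", "measured", "known", "first", "only" and "open" are said of these compounds alone.

In a physicochemical assay for lipophilicity, read by HPLC, measured as chromatographic lipophilicity, at pH 7.4 (on this read-out higher numbers stand for higher lipophilicity and lower numbers for lower lipophilicity), compound 3 `O=C(C1CCN(c2ccccc2)CC1)N1N=CCC1c1ccccc1` gives 6.3, level with compound 1 `O=C(C1CCN(c2ccccc2)CC1)N1N=CC[C@H]1c1ccccc1` at 6.3, and together they are the highest of the three numbers. That pair shows no change at the digits printed from compound 1 to compound 3 (within the scatter), the sole difference being (the fact that one of compounds 1 and 3 is drawn with a defined configuration and the other without, at the place where they differ). Compound 2 `CC(=O)N1CCC(C(=O)N2N=CC[C@H]2c2ccccc2)CC1` stands at 2.5. Compound 4 `O=C(c1cc[nH]n1)N1CCC(C(=O)N2N=CCC2c2ccccc2)CC1` departs from compound 3 by (1H-pyrazol-3-yl)carbonyl in place of phenyl on an amine nitrogen in a ring. The step bearing on this is a number 3.80 log units lower from compound 1 to compound 2 (beyond the scatter), where phenyl leaves the same place in favour of acetyl. A similarly large fall is therefore expected in this assay. The expected step is a number 3.30 log units lower from compound 3 to compound 4 (beyond the scatter). The estimated value for compound 4 is 3, with an expected range of 2.3 to 3.8.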

Compound 4, distribution coefficient: 2.4
Compound 4: middle estimate off by 0.60 log units, on the high side; measured number inside the range.
By their numbers in this assay, from the lowest: compounds 4 and 2 (each within the scatter of the next); then compounds 1 and 3 (each within the scatter of the next).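

In this assay, the large fall at this amine nitrogen in a ring is not confined to acetyl: the entering (1H-pyrazol-3-yl)carbonyl gives a number 3.90 log units lower from compound 3 to compound 4 (beyond the scatter). An aromatic ring in the entering group, here five-membered with 2 hetero atoms, therefore does not keep the number near that of the phenyl compound. The two phenyl compounds from which the falls start stand level, the sole difference being: the fact that one of compounds 1 and 3 is drawn with a defined configuration and the other without, at the place where they differ. Open, from the compounds shown here alone, is whether benzoyl or a plain ethyl on this nitrogen would fall as far. Such groups would help separate the part played by the carbonyl from that of the pyrazole ring.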